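A few compounds are considered here, and "the series" means these few. Any claim that something is new, unique, unknown or untested is made for them only; others in the source may bear on it.

The measured compounds:

compound 1, `CCCCCCCCS(=O)(=O)Nc1cc(-c2ccc(Cl)cc2)ccc1C(=O)O`, 18100 nM
compound 2, `CCCCCCCCS(=O)(=O)Nc1ccc(-c2cccc(Cl)c2)cc1C(=O)O`, 8900 nM
compound 3, `CCCCCCCCS(=O)(=O)Nc1cc(/C=C/c2ccccc2)ccc1C(=O)O`, 38000 nM

All three numbers come from an assay on mitochondria (strain BALB/c) for inhibition of glycerol-3-phosphate acyltransferase 1, mitochondrial (Mus musculus), read by scintillation counting, with a stated time of 10 min; on this read-out lower numbers stand for stronger inhibition and higher numbers for weaker inhibition. Compound 2 stands lowest of the three, and its steps to the other two lie beyond the scatter: compound 1 gives the nearest higher number, compound 3 the furthest. Among the compounds with values here, no single step connects compound 2 to either of them, so their values can only be set side by side. Compound 4, `CCCCCCCCS(=O)(=O)Nc1ccc(CCc2ccccc2)cc1C(=O)O`, has not yet been measured. It differs from compound 2 in one place: phenethyl in place of 3-chlorophenyl on an aromatic carbon.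

Within the data shown here, one measured step bears on this change. Going from compound 1 to compound 3, a chlorophenyl on the shared core gave way to a phenylethenyl, and the number rose: a 2.1-fold higher number from compound 1 to compound 3 (0.32 log units; beyond the scatter). In compound 4 a chlorophenyl again gives way to a two-carbon-linked phenyl, here the saturated phenethyl, on the same kind of position. A modest rise beyond the scatter is therefore expected from compound 2 to compound 4, in step with what compound 1 and compound 3 showed: a 2.0-fold higher number from compound 2 to compound 4 (0.31 log units; beyond the scatter). Compound 4 is accordingly estimated at 18000 nM, with a likely range from 7000 nM to 45000 nM.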

Compound 4, half-maximal inhibitory concentration: 37500 nM
For compound 4 the middle estimate is 2.1-fold (0.32 log units) below the measured one; the range from low to high includes it.
By their numbers in this assay, from the lowest: compound 2; then compound 1; then compounds 4 and 3 (each within the scatter of the next).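

In this assay, replacing 3-chlorophenyl with phenethyl at this position, meta to a carboxy group and para to a large group, gives a 4.2-fold higher number from compound 2 to compound 4 (0.62 log units; beyond the scatter). This is the first single-place step that starts from compound 2, and it runs the same way as a 2.1-fold higher number from compound 1 to compound 3 (0.32 log units; beyond the scatter), so among the compounds shown, both replacements of a chlorophenyl by a phenyl carried on a two-carbon link raise the number, and none goes against this. Nothing available here offers a measured explanation for the rise.

The compounds shown leave open which part of the change matters, as the chlorine leaves and the two-carbon link enters in the same step, so the two contributions cannot be separated. They also leave open how an unsubstituted phenyl, a benzyl or a phenoxy group would read at this position, and whether a 3-chlorophenethyl group, which keeps both the chlorine and the link, would restore the lower number seen with compound 2.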